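Side-chain variation on a shared core: notes toward compound 3

The source may report more compounds than this note shows. Statements on the series, on what has been measured and on what is new or still open speak of the compounds shown alone.

Compound 1, `Nc1ccc2cccc(OCCC3CCCCC3)c2n1`, in an assay on cells with melanin-concentrating hormone receptor 1 (Homo sapiens) as the target, read by radioligand binding; on this read-out higher numbers stand for weaker inhibition and lower numbers for stronger inhibition: 808 nM
Compound 2, `Nc1ccc2cccc(OCCC3CC3)c2n1`, in this assay: 492 nM

For the measured compounds named here, compound 2 stands at the smaller of the two numbers, with compound 1 as its only neighbour; the single step of a 1.6-fold lower number from compound 1 to compound 2 (0.22 log units; within the scatter) lies within the scatter, so no real order between the two can be claimed. Compound 3, `COCCOCCOc1cccc2ccc(N)nc12`, carries 2-methoxyethoxy in place of cyclopropyl on a saturated chain carbon, two bonds along the chain from an oxygen on an aromatic ring. Going by the values given here, the only measured step, a 1.6-fold lower number from compound 1 to compound 2 (0.22 log units; within the scatter), exchanges one carbocycle for another of different size and does not cover the exchange of a ring for an open ether chain; no measured pair does. Without a directly comparable step, a modest movement toward a higher number is expected, with wide uncertainty in either direction. For compound 3 the estimate in this assay is 900 nM, within 300 nM to 3000 nM, which means an expected 1.8-fold higher number from compound 2 to compound 3 (0.26 log units; within the scatter).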

Compound 3, half-maximal inhibitory concentration: > 2000 nM
Compound 3 gave a limit, no number; the forecaster's own chance of this, stated with the estimate: 5%; at least 2.2-fold (0.34 log units) between middle value and limit.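

In this assay compound 3 gives a limit and not a number: the limit of > 2000 nM in this assay, at which 1 of the 3 values shown sits.

Even so, the change reads clearly, with 2-methoxyethoxy in place of cyclopropyl giving an at least 4.0-fold higher number from compound 2 to compound 3 (0.60 log units; beyond the scatter), and 2-methoxyethoxy in place of cyclohexyl giving an at least 2.4-fold higher number from compound 1 to compound 3 (0.39 log units; beyond the scatter). The earlier pair showed no readable difference between two carbocycles (a 1.6-fold lower number from compound 1 to compound 2 (0.22 log units; within the scatter)), whereas this place on the chain does respond once an open ether chain replaces the ring, so it is not indifferent to the group it carries.

From the compounds shown here alone, how far compound 3 lies past its limit stays open, so these steps give only a floor for the size of the change. Whether the ether oxygens or the loss of the ring account for it also stays open; an open all-carbon chain such as butyl, or a tetrahydropyranyl ring, would separate the two.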